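This account rests on a few compounds, and the source may have more. Where it says the series, first, only, none or still open, it means among the compounds named here.

Measured compounds in an ADME assay for permeability, using PAMPA, at pH 7.4; a lower number here means that the compound crosses the layer more slowly, a higher number that the compound crosses the layer faster:

- compound 1 `CC(=O)c1ccc(NC(=O)Nc2cc(C)nc3ccccc23)cc1` gives 473 10^-6 cm/s
- compound 2 `Cc1cc(NC(=O)Nc2cccc3nsnc23)c2ccccc2n1` gives 155 10^-6 cm/s
- compound 3 `COC(=O)c1cccc(NC(=O)Nc2cc(C)nc3ccccc23)c1` gives 746 10^-6 cm/s

Among these three numbers compound 1 holds the second highest. Its nearest neighbour is compound 3, whose higher number lies within the scatter of the method, so the two cannot be told apart. The furthest is compound 2, whose lower number lies beyond the scatter.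

The next compound in this series is compound 4 `Cc1cc(NC(=O)Nc2ccc(N)cc2)c2ccccc2n1`, which keeps the core of compound 1 and changes one group on the outer six-membered ring: amino in place of acetyl on an aromatic carbon. For the measured compounds named here, no step between measured compounds shows the effect of such a change, so the expectation rests on compound 1 alone. The change trades a group with no donor for one with a donor, and the author expects a modest downward step in this assay, of a size that may or may not clear the scatter; the step from compound 1 to compound 4 is estimated at a 1.7-fold lower number from compound 1 to compound 4 (0.23 log units; within the scatter). The author therefore expects compound 4 to give about 280 10^-6 cm/s, with a likely range from 120 10^-6 cm/s to 650 10^-6 cm/s.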

Compound 4, apparent permeability: 530 10^-6 cm/s
For compound 4 the middle estimate is 1.9-fold (0.28 log units) below the measured one; low and high end bracket the measured number.
By their numbers in this assay, from the lowest: compound 2; then compounds 1, 4 and 3 (each within the scatter of the next).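

Amino in place of acetyl on an aromatic carbon, para to a large group, gives a 1.1-fold higher number from compound 1 to compound 4 (0.05 log units; within the scatter) in this assay, so the two compounds cannot be told apart. For the compounds shown here, this is the first step that can be read at all, and it shows that at this position a hydrogen-bond donor can enter and two heavy atoms can leave with no step beyond the scatter. Nothing measured here offers an explanation for this result.

As far as these compounds go, whether other groups at this position, such as a hydroxyl, a carboxylic acid or a dimethylamino group, would also stay within the scatter remains open. Also open, from the compounds shown here alone, is whether amino in place of acetyl would give a similar step elsewhere on this ring.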